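Triazole series: carbamate in place of benzyl ether

This account rests on a few compounds, and the source may have more. Where it says the series, first, only, none or still open, it means among the compounds named here.

Measured so far:
compound 1, `CCCCC(O)Cn1cc(CN(C)CC2CCCCC2)nn1`, 47%
compound 2, `CN(Cc1cn(CC(O)COCc2ccccc2)nn1)CC1CCCCC1`, 6%

Among the measured compounds shown here, in an assay on nucleic acid for inhibition of Nucleic Acid, read by fluorescence, tested at 100 uM (a higher number here means more inhibition at the concentration tested (going by the name of the read-out), a lower number less inhibition), compound 2 gives the lower of the two numbers; compound 1 gives 47% and the only measured step, a number 41 percentage points lower from compound 1 to compound 2 (beyond the scatter), lies beyond the scatter. Compound 3, `CCCCNC(=O)OCC(O)Cn1cc(CN(C)CC2CCCCC2)nn1`, is not yet measured. Its change from compound 2 is butylcarbamoyl in place of benzyl on an oxygen on a saturated carbon. For the measured compounds named here, no measured step covers this exact exchange; the only one that bears on the same region is a number 41 percentage points lower from compound 1 to compound 2 (beyond the scatter), where benzyloxy entering in place of propyl cost heavily. Since compound 3 removes the benzyl again and puts in a chain-bearing group, a recovery of part of that loss is expected, but the direction is uncertain and the estimate is kept cautious: the step of a number 16 percentage points higher from compound 2 to compound 3 (beyond the scatter) is expected. Compound 3 is therefore estimated at 22%, within 0% to 48%.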

Compound 3, a percentage reported as inhibition, at one concentration (the size of the read-out at that concentration, not a potency): 12%
Compound 3: the middle estimate sits 10 percentage points above what was measured; the measured number falls inside the stated range.
By their numbers in this assay, from the lowest: compounds 2 and 3 (each within the scatter of the next); then compound 1.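

In this assay, butylcarbamoyl on this oxygen in place of benzyl gives a number 6 percentage points higher from compound 2 to compound 3 (within the scatter), so the two groups cannot be told apart here, although butylcarbamoyl has no ring and brings a hydrogen-bond donor that benzyl lacks. Compared with the propyl of compound 1, (butylcarbamoyl)oxy gives a number 35 percentage points lower from compound 1 to compound 3 (beyond the scatter), which shows that the large step of a number 41 percentage points lower from compound 1 to compound 2 (beyond the scatter) is not peculiar to benzyloxy: both oxygen-linked groups lie on the same side of compound 1. No measurement here explains this result.

Open, from the compounds shown here alone, is whether the oxygen on this chain or the overall length of the group goes with the low numbers, which a plain hexyl or octyl chain at this place would separate. Also open, going by these compounds, is how a small methoxy group or a primary amine would read there.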